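Toxicity of the methylpiperidine analogue in the series

This account rests on a few compounds, and the source may have more. Where it says the series, first, only, none or still open, it means among the compounds named here.

Three compounds share one core. Compound 1 `COc1cc(Cc2cnc(/N=C3\C(=O)N(CN4CCN(c5c(F)cc6c(=O)c(C(=O)O)cn(C7CC7)c6c5F)CC4C)c4ccc(Cl)cc43)nc2N)cc(OC)c1OC` carries the largest side arm and gives "not determined" (no result reported) in an ADME assay on MT4 cells (Homo sapiens) for cytotoxicity, read by MTT assay, with a stated time of 5 days (on this read-out higher numbers stand for lower toxicity in this test and lower numbers for higher toxicity in this test), so no number is known for it. Compound 2 `COc1cc(Cc2cnc(/N=C3\C(=O)N(CN4CCN(c5ccc(F)cc5)CC4)c4ccc(Cl)cc43)nc2N)cc(OC)c1OC` gives 65.6 ug/mL in this assay. Among the measured compounds shown here, compound 3 `COc1cc(Cc2cnc(/N=C3\C(=O)N(CN4CCN(c5ccccn5)CC4)c4ccc(Cl)cc43)nc2N)cc(OC)c1OC` gives 39.2 ug/mL in this assay, the lowest of the two numbers known; the step of a 1.7-fold lower number from compound 2 to compound 3 (0.22 log units; within the scatter) stays within the scatter, so compounds 2 and 3 are not told apart on this read-out.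

The next compound, compound 4 `COc1cc(Cc2cnc(/N=C3\C(=O)N(CN4CCCCC4C)c4ccc(Cl)cc43)nc2N)cc(OC)c1OC`, differs from compound 3 by 2-methylpiperidin-1-yl in place of 4-(pyridin-2-yl)piperazin-1-yl on a saturated chain carbon bound to an amide-type nitrogen in a ring. For the measured compounds named here, the one measured step, from compound 2 to compound 3, keeps the piperazine and only exchanges the group on its far nitrogen, so it bears on the present change only loosely; it shows that such an exchange left this assay essentially unmoved. Going by the values given here, no measured step removes the piperazine itself, so the expectation rests on the two numbers at hand and is held wide.

Compound 4 is therefore expected to sit near the two measured compounds, with an estimated step of a 1.3-fold higher number from compound 3 to compound 4 (0.11 log units; within the scatter) that is not beyond the scatter. The estimate for compound 4 in this assay is 50 ug/mL, within 20 ug/mL to 125 ug/mL.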

Compound 4, half-maximal cytotoxic concentration: 97.3 ug/mL
Compound 4: middle estimate off by 1.9-fold (0.29 log units), on the low side; the measured number falls inside the stated range.
By their numbers in this assay, from the lowest: compounds 3, 2 and 4 (each within the scatter of the next, the first and the last beyond it).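

Among the compounds shown here, exchanging the whole 4-(pyridin-2-yl)piperazin-1-yl group for 2-methylpiperidin-1-yl gives a 2.5-fold higher number from compound 3 to compound 4 (0.39 log units; beyond the scatter) in this assay and is the first step to pass the scatter, though only modestly. The earlier step changed only the group on the far nitrogen of the piperazine, whereas this one changes the ring amine on the saturated chain carbon itself and moves the number toward lower toxicity in this test, on this one pair alone. No measurement at hand accounts for this shift.

Going by these compounds, the step removes the aromatic ring, replaces the piperazine and adds a methyl group all at once, so which of these parts carries the shift remains open. An unsubstituted piperidin-1-yl or a morpholin-4-yl in the same place would begin to separate them.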